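From 2-methylphenyl to 3-chlorophenyl at an assay limit

The source may report more compounds than this note shows. Statements on the series, on what has been measured and on what is new or still open speak of the compounds shown alone.

Compound 1 `C/C(=C\CC/C(C)=C/CC[C@@H]1[C@@]2(C)CCC(=O)C(C)(C)[C@H]2CC[C@@]1(C)O)CC/C=C(\C)C(=O)OCc1cn(-c2cccc(C)c2)nn1` | > 150000 nM (a limit of the assay)
Compound 2 `C/C(=C\CC/C(C)=C/CC[C@@H]1[C@@]2(C)CCC(=O)C(C)(C)[C@H]2CC[C@@]1(C)O)CC/C=C(\C)C(=O)OCc1cn(-c2ccccc2C)nn1` | > 150000 nM (a limit of the assay)

In an ADME assay on L132 cells (Homo sapiens) for cytotoxicity, read by MTT assay, with a stated time of 48 h (a lower number here means a stronger inhibitor, a higher number a weaker inhibitor), compound 2 gives > 150000 nM as its result, which is a limit and not a number. Both measured compounds stand at the limit of > 150000 nM in this assay, at which 2 of the 2 values shown sit, so no order can be drawn between them.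

Compound 3 `C/C(=C\CC/C(C)=C/CC[C@@H]1[C@@]2(C)CCC(=O)C(C)(C)[C@H]2CC[C@@]1(C)O)CC/C=C(\C)C(=O)OCc1cn(-c2cccc(Cl)c2)nn1` carries 3-chlorophenyl in place of 2-methylphenyl on an aromatic nitrogen. Among the measured compounds shown here, the only measured step that bears on this change is a step that the two limits leave unreadable from compound 1 to compound 2 and it swaps 3-methylphenyl for 2-methylphenyl on that same aromatic nitrogen. Its size cannot be read, so it offers no number to carry over, although neither compound gave a reading away from the limit.

No step beyond the scatter is therefore expected in this assay and no direction can be named. The expected change, a number no higher from compound 2 to compound 3 (the limit leaves the size open), is only an estimate made close to the limit, and another limit is the likeliest report. Compound 3 is estimated at 150000 nM with an expected range of 75000 nM to 300000 nM for this assay.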

Compound 3, half-maximal inhibitory concentration: 94200 nM
Compound 3: the middle estimate sits 1.6-fold (0.20 log units) above what was measured, and the stated range covers the measured number.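

In this assay compound 3 gives 94200 nM, a measured number and not a limit, so this place on the aromatic nitrogen now has a reading that can be compared with later changes. Putting 3-chlorophenyl in place of 2-methylphenyl gives an at least 1.5-fold lower number from compound 2 to compound 3 (0.20 log units; that floor lies within the scatter), and putting chloro in place of methyl on an aromatic carbon gives an at least 1.5-fold lower number from compound 1 to compound 3 (0.20 log units; that floor lies within the scatter). Both steps are floors rather than exact sizes, and the true gaps could be larger or could stay within the scatter, as the other two compounds have no number of their own: the limit of > 150000 nM in this assay, at which 2 of the 3 values shown sit.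

The step between compound 1 and compound 2 cannot be read, so the compounds shown say nothing about whether moving the methyl around the phenyl ring matters, and a single chlorine-bearing compound cannot show whether the reading follows the chlorine itself or where it sits. Also open, from the compounds shown here alone, is how 2-chlorophenyl would read, and whether a phenyl ring carrying an amine or a carboxylic acid at this place would also give a number rather than a limit.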